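Series notes: 3-fluorophenyl replaces 4-fluorobenzyl

The source may report more compounds than this note shows. Statements on the series, on what has been measured and on what is new or still open speak of the compounds shown alone.

Of the compounds shown here, two have been measured in a functional assay with Homo sapiens as the target; on this read-out lower numbers stand for stronger inhibition and higher numbers for weaker inhibition. Compound 1 `Cc1c(C(=O)Nc2ccc(C(F)(F)F)cc2)cnn1Cc1ccc(F)cc1` gives 3600 nM in this assay. Compound 2 `COc1cccc(NC(=O)c2cnn(-c3ccc(F)cc3)c2C)c1` differs from compound 1 in several places. In this assay compound 2 gives 3700 nM. Going by the values given here, the two numbers lie within the usual scatter of each other, so compound 1 and compound 2 cannot be told apart on potency, and no single-point step between measured compounds is available.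

Compound 3 `Cc1c(C(=O)Nc2ccc(C(F)(F)F)cc2)cnn1-c1cccc(F)c1` remains to be measured in this assay. It differs from compound 1 by 3-fluorophenyl in place of 4-fluorobenzyl on an aromatic nitrogen. The group that leaves and the group that enters are both fluorine-bearing six-membered aromatic rings of carbon only, differing by one heavy atom in the count given above. Among the compounds with values here, no measured pair shows what such a change does here, so the expected step from compound 1 to compound 3 is taken as none beyond the scatter, with the range widened to allow for a shift in either direction.

Compound 3 is therefore expected to give about 4000 nM in this assay, within a range from 1200 nM to 13000 nM, an expected step of a 1.1-fold higher number from compound 1 to compound 3 (0.05 log units; within the scatter).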

Compound 3, half-maximal inhibitory concentration: 3100 nM
For compound 3 the middle estimate is 1.3-fold (0.11 log units) above the measured one; the range from low to high includes it.
By their numbers in this assay, from the lowest: compounds 3, 1 and 2 (each within the scatter of the next).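

Going by these compounds alone, on the aromatic nitrogen, 3-fluorophenyl in place of 4-fluorobenzyl gives a 1.2-fold lower number from compound 1 to compound 3 (0.06 log units; within the scatter) in this assay, the only single-place step so far, and it lies within the scatter. This position therefore takes either fluorine-bearing ring with no potency difference that can be read, something compound 1 and compound 2 could not show, as they differ in several places. Nothing at hand bears on what lies behind this result.

As far as these compounds go, the step combines two differences, the loss of one heavy atom and the new place of the fluorine on the ring, and it remains open which of them, if either, matters on its own; 3-fluorobenzyl on the same nitrogen, with the rest of compound 1 kept, would separate them. Also open, from the compounds shown here alone, is whether this position stays as undemanding for groups of another kind, such as a longer alkyl chain, a ring carrying an amine or a carboxylic acid, since both groups compared here are fluorine-bearing six-membered aromatic rings of carbon only.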